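The source may report more compounds than this note shows. Statements on the series, on what has been measured and on what is new or still open speak of the compounds shown alone.

Measured compounds:
Compound 1 `O=C(CSc1cccc(O)c1)Nc1ccc2nc(NC(=O)c3ccccc3)sc2c1` gives 41000 nM in a functional assay on HCT-116 cells (Homo sapiens) for antiproliferative activity, read by MTT assay, with a stated time of 72 h; on this read-out higher numbers stand for weaker inhibition and lower numbers for stronger inhibition.
Compound 2 `O=C(Cn1cc(F)c(=O)n(CC(=O)Nc2ccc(Br)cn2)c1=O)Nc1ccc(Br)cn1` gives 11100 nM in this assay.

Of these two numbers, compound 1 stands highest; compound 2 gives the lower number, and the gap between the two lies beyond the usual scatter of repeated measurements. The two structures differ in many places, so nothing more than the two values themselves can be read from that gap.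

Compound 3 `Cc1ccc(C(=O)Nc2nc3ccc(NC(=O)CSc4cccc(O)c4)cc3s2)cc1` has not yet been measured. It differs from compound 1 in a single place: methyl in place of hydrogen on an aromatic carbon. Among the measured compounds shown here, no step between measured compounds of this kind is available, so the expected size of the change rests on the single-atom nature of the difference alone. The step of a 1.4-fold lower number from compound 1 to compound 3 (0.14 log units; within the scatter) is expected to be small, likely within the scatter, with at most a slight move toward a lower number. For compound 3 the estimate in this assay is 30000 nM, with a range from 10000 nM to 90000 nM.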

Compound 3, half-maximal inhibitory concentration: 7730 nM
The estimate for compound 3 lay 3.9-fold (0.59 log units) above the measured number, and the stated range ends above it.
By their numbers in this assay, from the lowest: compounds 3 and 2 (each within the scatter of the next); then compound 1.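

Turning the phenyl of compound 1 into the 4-methylphenyl of compound 3 gives a 5.3-fold lower number from compound 1 to compound 3 (0.72 log units; beyond the scatter) in this assay, so a single added carbon is enough to move the number toward stronger inhibition. Among the compounds shown here, this shows that the aromatic carbon para to a large group is not indifferent to substitution, which the earlier compounds, differing in many places, could not show. Nothing available accounts for the size of this step.

As far as these compounds go, with only one substituent at this position, it remains open whether the gain is particular to methyl or would also follow with a chlorine atom, a methoxy group or an amine in its place. From the compounds shown here alone, it is equally open whether a longer chain, such as ethyl or propyl, would extend the change or reverse it.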